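This account rests on a few compounds, and the source may have more. Where it says the series, first, only, none or still open, it means among the compounds named here.

Measured so far, in a functional assay on MCF7 cells (Homo sapiens) for inhibition, read by MTT assay, with a stated time of 72 h; a higher number here means a weaker inhibitor, a lower number a stronger inhibitor:
compound 1 `CN(C(=O)NC(=O)c1ccc(F)c(F)c1)c1nc(C(F)(F)F)c(C(=O)N/N=C/c2ccc(C(F)(F)F)cc2)s1` gives 5.93 ug/mL
compound 2 `CN(C(=O)NC(=O)c1ccc(Cl)cc1Cl)c1nc(C(F)(F)F)c(C(=O)N/N=C/c2ccc(C(F)(F)F)cc2)s1` gives 8.42 ug/mL
compound 3 `CN(C(=O)NC(=O)c1ccc(F)c(F)c1)c1nc(C(F)(F)F)c(C(=O)N/N=C/c2ccccc2C(F)(F)F)s1` gives 8.21 ug/mL

All three values sit close together. Compound 2 differs from compound 1 by one change, (2,4-dichlorophenyl in place of 3,4-difluorophenyl on a carbonyl carbon), and the step in this assay is a 1.4-fold higher number from compound 1 to compound 2 (0.15 log units; within the scatter). Compound 3 differs from compound 1 at another place, (2-(trifluoromethyl)phenyl in place of 4-(trifluoromethyl)phenyl on a carbon with a double bond to nitrogen), with a step of a 1.4-fold higher number from compound 1 to compound 3 (0.14 log units; within the scatter). Going by the values given here, no step is counted between compound 2 and compound 3; their two values show almost nothing between them.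

Compound 4 `CN(C(=O)NC(=O)c1ccc(Cl)cc1Cl)c1nc(C(F)(F)F)c(C(=O)N/N=C/c2ccccc2C(F)(F)F)s1` has not yet been measured in this assay. It stands to compound 3 as compound 2 stands to compound 1: the change is 2,4-dichlorophenyl in place of 3,4-difluorophenyl on a carbonyl carbon, and the place is the same, word for word, as in the earlier pair. The two cores differ by 2-(trifluoromethyl)phenyl in place of 4-(trifluoromethyl)phenyl on a carbon with a double bond to nitrogen. Among the compounds with values here, since the one measured instance of this change gave a 1.4-fold higher number from compound 1 to compound 2 (0.15 log units; within the scatter), the step to compound 4 in this assay is expected to be of the same order, a 1.4-fold higher number from compound 3 to compound 4 (0.15 log units; within the scatter), resting on that single earlier pair and on compound 3 at 8.21 ug/mL. Compound 4 is accordingly estimated at 11.5 ug/mL, with a likely range from 6 ug/mL to 22 ug/mL.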

Compound 4, half-maximal inhibitory concentration: 9.12 ug/mL
For compound 4 the middle estimate is 1.3-fold (0.10 log units) above the measured one; the measured number falls inside the stated range.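

In this assay, 2,4-dichlorophenyl in place of 3,4-difluorophenyl on the carbonyl carbon gives a 1.1-fold higher number from compound 3 to compound 4 (0.05 log units; within the scatter), and this agrees with the earlier step on the other core: the same change on two cores in this assay, a 1.4-fold higher number (0.15 log units; within the scatter) from compound 1 to compound 2 and a 1.1-fold higher number (0.05 log units; within the scatter) from compound 3 to compound 4, 1.3-fold (0.11 log units) apart, within the scatter of two such steps. The change from 4-(trifluoromethyl)phenyl to 2-(trifluoromethyl)phenyl gives a 1.1-fold higher number from compound 2 to compound 4 (0.03 log units; within the scatter), and it also agrees with its earlier counterpart: the same change on two cores in this assay, a 1.4-fold higher number (0.14 log units; within the scatter) from compound 1 to compound 3 and a 1.1-fold higher number (0.03 log units; within the scatter) from compound 2 to compound 4, 1.3-fold (0.11 log units) apart, within the scatter of two such steps. Each change therefore carries between these two cores without a detectable difference, but with all four steps within the scatter, this does not show that either change has a real effect of its own, or that a real effect would transfer.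

The compounds shown leave open whether this agreement holds for a simple amine or a carboxylic acid in place of the aryl group on the carbonyl carbon, or for a longer alkyl chain in place of the aryl group on the carbon with a double bond to nitrogen. They also leave open how a change giving a step beyond the scatter would behave from one core to another.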